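The source may report more compounds than this note shows. Statements on the series, on what has been measured and on what is new or still open speak of the compounds shown alone.

Compound 1 `COc1ccc(-c2noc(C3CCCN3)n2)cc1OC1CCCC1`: 43 nM
Compound 2 `COc1ccc(-c2noc(C3CCNCC3)n2)cc1OC1CCCC1`: 10 nM
Compound 3 `COc1ccc(-c2noc(-c3ccc(F)cc3)n2)cc1OC1CCCC1`: 87900 nM

In a functional assay on LNCaP cells (Homo sapiens) for antiproliferative activity, read by MTT assay, with a stated time of 24 h (on this read-out lower numbers stand for stronger inhibition and higher numbers for weaker inhibition), compound 3 has the highest number of the three, at 87900 nM. Compound 4 `COc1ccc(-c2noc(-c3cccnc3)n2)cc1OC1CCCC1` carries pyridin-3-yl in place of 4-fluorophenyl on an aromatic carbon. The closest evidence is a 2000-fold higher number from compound 1 to compound 3 (3.31 log units; beyond the scatter) and an 8800-fold higher number from compound 2 to compound 3 (3.94 log units; beyond the scatter), both large, which place 4-fluorophenyl where pyrrolidin-2-yl or piperidin-4-yl stood. The step of a 4.3-fold lower number from compound 1 to compound 2 (0.63 log units; beyond the scatter) is modest by comparison. Within the data shown here, no measured step exchanges one aromatic ring for another, and compound 4 keeps an aromatic ring at this place, so a recovery on the scale of those large steps is not expected. The expected change is a modest one, a 4.4-fold lower number from compound 3 to compound 4 (0.64 log units; beyond the scatter). For compound 4 the estimated value is 20000 nM, with an expected range from 2000 nM to 100000 nM.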

Compound 4, half-maximal inhibitory concentration: > 1000000 nM
Compound 4 ended at the assay's limit; the forecaster's own chance of this, stated with the estimate: 10%; middle value at least 50-fold (1.69 log units) from the limit.
By their numbers in this assay, from the lowest: compound 2; then compound 1; then compound 3. At a limit, above all of these: compound 4.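

Among these compounds, exchanging one aromatic ring for another at this place, a change no earlier step covered, is itself a large step: an at least 11-fold higher number from compound 3 to compound 4 (1.05 log units; beyond the scatter). Among the compounds shown here, measured against the two nitrogen-bearing groups of the earlier compounds, the gaps grow to an at least 100000-fold higher number from compound 2 to compound 4 (5.00 log units; beyond the scatter) and an at least 23000-fold higher number from compound 1 to compound 4 (4.36 log units; beyond the scatter). The reading for compound 4 is a limit of the assay and not a number: the limit of > 1000000 nM in this assay, at which 1 of the 4 values shown sits.

Still open, going by these compounds, is whether plain phenyl or pyridin-4-yl would follow 4-fluorophenyl or pyridin-3-yl. An open-chain amine such as aminomethyl might or might not keep the low numbers of compound 1 and compound 2.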